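This account rests on a few compounds, and the source may have more. Where it says the series, first, only, none or still open, it means among the compounds named here.

Measured in a functional assay on MDA-MB-435 cells (Homo sapiens) for inhibition, read by MTT assay, with a stated time of 72 h; on this read-out lower numbers stand for stronger inhibition and higher numbers for weaker inhibition:
- compound 1 `COC(=O)c1ccc(-c2ccc(-c3ccc(O)cc3)c(OC)c2OC)cc1O`: 20900 nM
- compound 2 `COc1c(-c2ccc(O)cc2)ccc(-c2ccc(O)c(C(=O)O)c2)c1OC`: > 100000 nM, a limit

Among the compounds with values here, compound 1, at 20900 nM, holds the only actual number in this small set. Compound 2 gives > 100000 nM, which is a limit of the assay and not a number.

Compound 3 `COc1c(-c2ccc(O)cc2)ccc(-c2ccc(C(=O)O)c(O)c2)c1OC` changes compound 1 in one place: hydrogen in place of methyl on an oxygen next to a carbonyl group. Hydrogen replaces methyl on an oxygen next to a carbonyl group, so methoxycarbonyl becomes carboxy. Within the data shown here, no measured pair shows this change directly. Among the measured compounds shown here, the only guide is compound 2, which also carries a carboxy group and reads > 100000 nM, a limit. A step beyond the usual scatter towards weaker inhibition in this assay is therefore expected. The estimated size is a 3.3-fold higher number from compound 1 to compound 3 (0.52 log units; beyond the scatter). Compound 3 is expected near 70000 nM, with an estimated range of 25000 nM to 200000 nM.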

Compound 3, half-maximal inhibitory concentration: > 100000 nM
Compound 3 ended at the assay's limit; the forecaster's own chance of this, stated with the estimate: 50%; middle value at least 1.4-fold (0.15 log units) from the limit.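

Replacing methyl with hydrogen on an oxygen next to a carbonyl group, which turns methoxycarbonyl into carboxy, now has a direct reading in this assay: the change gives an at least 4.7-fold higher number from compound 1 to compound 3 (0.67 log units; beyond the scatter). Compound 3 gives > 100000 nM, a limit of the assay and not a number, so this step marks only the smallest size the change can have. The methyl on this oxygen therefore matters in this assay, and the full size of its loss stays hidden because the read-out stops at this limit: the limit of > 100000 nM in this assay, at which 2 of the 3 values shown sit.

The compounds shown leave open whether another group in this place, such as an amide or a longer ester like ethoxycarbonyl, would keep the inhibition seen with compound 1. They also leave open how far compound 3 lies beyond the limit.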